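A double bond enters the chain of compound 3

This account rests on a few compounds, and the source may have more. Where it says the series, first, only, none or still open, it means among the compounds named here.

Of the compounds shown here, three that share one core have been measured in an ADME assay for permeability, using PAMPA, with a stated time of 4 h, at pH 7.4; a higher number here means that the compound crosses the layer faster, a lower number that the compound crosses the layer more slowly. Compound 1 (`NCCCCN(C[C@H]1Cc2ncccc2CN1)[C@H]1CCCc2cccnc21`) gives 14 nm/s, compound 2 (`NC/C=C\CN(C[C@H]1Cc2ncccc2CN1)[C@H]1CCCc2cccnc21`) gives 68 nm/s, and compound 3 (`NC(=O)NCCCCN(C[C@H]1Cc2ncccc2CN1)[C@H]1CCCc2cccnc21`) gives 2 nm/s, the lowest of the three numbers. Compound 4 (`NC(=O)NC/C=C/CN(C[C@H]1Cc2ncccc2CN1)[C@H]1CCCc2cccnc21`) has not yet been measured. It differs from compound 3 on a saturated chain carbon bound to an amine nitrogen: a group of 7 heavy atoms (4 carbon, 2 nitrogen, 1 oxygen; no ring) in place of a group of 7 heavy atoms (4 carbon, 2 nitrogen, 1 oxygen; no ring), on a saturated chain carbon bound to an amine nitrogen. The 3-ureidopropyl group leaves, and the group that enters has no common name.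

The nearest measured parallel is a 4.9-fold higher number from compound 1 to compound 2 (0.69 log units; beyond the scatter), a modest step in which 3-aminoprop-1-en-1-yl takes the place of 3-aminopropyl, and it points to a higher number for compound 4. Within the data shown here, the parallel is imperfect: the double bond is cis in compound 2 and trans in compound 4, and no measured pair shows this change with carbamoyl present. Two further steps, a 7.0-fold lower number from compound 1 to compound 3 (0.85 log units; beyond the scatter) and a 34-fold lower number from compound 2 to compound 3 (1.53 log units; beyond the scatter), involve carbamoyl, which compound 3 and compound 4 both carry, and they bear on this change only indirectly. In this assay, a modest upward move is expected, estimated as a 3.0-fold higher number from compound 3 to compound 4 (0.48 log units; beyond the scatter). Compound 4 is estimated at 6 nm/s, with an expected range of 2 nm/s to 18 nm/s.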

Compound 4, apparent permeability: 2 nm/s
Estimate against measurement, compound 4: 3.0-fold (0.48 log units) above; the range from low to high includes it.
By their numbers in this assay, from the lowest: compounds 3 and 4 (each within the scatter of the next); then compound 1; then compound 2.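

With carbamoyl on the chain, the trans double bond gives no change at the digits printed from compound 3 to compound 4 (within the scatter) in this assay, so the rise seen when a cis double bond entered the chain without carbamoyl, a 4.9-fold higher number from compound 1 to compound 2 (0.69 log units; beyond the scatter), does not carry over to this pair. The two compounds that end in a plain amine remain well clear of the new compound, with a 7.0-fold lower number from compound 1 to compound 4 (0.85 log units; beyond the scatter) and a 34-fold lower number from compound 2 to compound 4 (1.53 log units; beyond the scatter), and these are the same sizes as the steps to compound 3; among these four compounds, then, the low numbers go with carbamoyl, whether or not the chain holds a double bond. No measurement is available that gives a cause for the flat result in this pair.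

On these data alone, whether the cis or the trans form of the double bond matters stays open: each form appears here with only one chain end, the cis form with the amine and the trans form with carbamoyl. Also open, as far as these compounds go, is how the number would respond to an acetyl group or a carboxylic acid at the end of the chain, or to a longer chain.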